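This account rests on a few compounds, and the source may have more. Where it says the series, first, only, none or still open, it means among the compounds named here.

Among the compounds with values here, in a functional assay on Mahlavu cells (Homo sapiens) for antiproliferative activity, read by sulforhodamine B assay, with a stated time of 72 h (on this read-out higher numbers stand for weaker inhibition and lower numbers for stronger inhibition), compound 3 `COc1ccccc1COc1ccc(-c2cc(CN3CCN(Cc4ccc(C(F)(F)F)cc4)CC3)no2)cc1` gives 3900 nM, the lowest of the three numbers measured so far, though the neighbours sit close: compound 2 `N#Cc1ccc(COc2ccc(-c3cc(CN4CCN(Cc5ccc(C(F)(F)F)cc5)CC4)no3)cc2)cc1` gives 4300 nM and compound 1 `Cc1ccc(COc2ccc(-c3cc(CN4CCN(Cc5ccc(C(F)(F)F)cc5)CC4)no3)cc2)cc1` gives 7500 nM. The step of a 1.9-fold lower number from compound 1 to compound 3 (0.28 log units; within the scatter) and the step of a 1.1-fold lower number from compound 2 to compound 3 (0.04 log units; within the scatter) both stay within the scatter, as does a 1.7-fold lower number from compound 1 to compound 2 (0.24 log units; within the scatter). Within the data shown here, compound 4 `COc1cc(COc2ccc(-c3cc(CN4CCN(Cc5ccc(C(F)(F)F)cc5)CC4)no3)cc2)cc(OC)c1` differs from compound 3 at the same position that the earlier steps varied: 3,5-dimethoxyphenyl in place of 2-methoxyphenyl on a saturated chain carbon bound to an oxygen on an aromatic ring. The two measured steps that bear on this change, from compound 1 and from compound 2 to compound 3, both exchanged the aryl group on this saturated chain carbon without moving the number beyond the scatter, so the exchange of 2-methoxyphenyl for 3,5-dimethoxyphenyl is expected to behave the same way, giving no step beyond the scatter in this assay. The estimate for compound 4 in this assay is therefore 4000 nM, with a range from 1500 nM to 11000 nM, which means an expected step of a 1.0-fold higher number from compound 3 to compound 4 (0.01 log units; within the scatter).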

Compound 4, half-maximal inhibitory concentration: 4300 nM
Compound 4: middle estimate off by 1.1-fold (0.03 log units), on the low side, and the stated range covers the measured number.
By their numbers in this assay, from the lowest: compounds 3, 2, 4 and 1 (each within the scatter of the next).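

The steps of a 1.1-fold higher number from compound 3 to compound 4 (0.04 log units; within the scatter) and no change at the digits printed from compound 2 to compound 4 (within the scatter) and a 1.7-fold lower number from compound 1 to compound 4 (0.24 log units; within the scatter) all stay within the scatter in this assay, so compound 4 cannot be placed apart from any of the three earlier compounds. Compound 4 extends the earlier picture to 3,5-dimethoxyphenyl, with 10 heavy atoms and 2 hydrogen-bond acceptors against 8 and 1 for the 2-methoxyphenyl it replaces, and even this difference on the saturated chain carbon leaves the number within the scatter. Nothing available here accounts for this flat result.

The compounds shown leave open whether a carboxylic acid or an amine on this aryl ring, or a longer chain in place of the single saturated chain carbon, would move the number beyond the scatter. Since all four numbers lie within the scatter of one another, they also give no ranking of the aryl groups tried at this position.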